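Configuration Alone Separates Compound 2 From Compound 3

This account rests on a few compounds, and the source may have more. Where it says the series, first, only, none or still open, it means among the compounds named here.

Compound 1 `NC(=S)N/N=C1\CCCc2cccnc21` and compound 2 `C=CCNC(=S)N/N=C1/CCCc2cccnc21` share a core and have both been tested in a toxicity assay on the whole organism (P388 cells, strain CDF1) for cytotoxicity, with Mus musculus as the target, with stated times of 6 days and 24 h, at a dose of 10 mg/kg; a higher number here means a weaker effect of the compound at the dose given, a lower number a stronger effect. In this assay compound 1 gives -10.7%. In this assay compound 2 gives -6.1%. As written, the number for compound 2 is the higher of the two, but its nearest neighbour, compound 1, sits within the usual scatter of it, so the two cannot be told apart and neither can be called stronger or weaker.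

Compound 3 `C=CCNC(=S)N/N=C1\CCCc2cccnc21` has not yet been measured. It differs from compound 2 in this way: the two compounds have the same atoms and bonds and differ only in configuration as drawn: 1 of 1 stereo elements differ; a double bond is drawn Z in compound 2 and E in compound 3. Nothing leaves and nothing enters. Among the measured compounds shown here, no measured pair in this set differs in one place, so no step of this kind is known. Because compound 2 gives -6.1% and compound 1 lies within the scatter of that number, the step from compound 2 to compound 3 is expected to be a number 1.9 percentage points lower from compound 2 to compound 3 (within the scatter), within the scatter in either direction. Compound 3 is therefore expected to give about -8% in this assay, with a range from -25% to 10%.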

Compound 3, a percentage reported as activity, at one dose (the size of the read-out at that dose, not a potency): -9.1%
Beside the measured number, compound 3's estimate is 1.1 percentage points above it; low and high end bracket the measured number.
By their numbers in this assay, from the lowest: compounds 1, 3 and 2 (each within the scatter of the next).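

In this assay, turning the double bond from Z to E with the allyl group kept in place gives a number 3 percentage points lower from compound 2 to compound 3 (within the scatter), so at this double bond the change of configuration leaves no difference that can be read at this dose. Placing allyl instead of hydrogen on the amide-type nitrogen, with the E double bond kept, gives a number 1.6 percentage points higher from compound 1 to compound 3 (within the scatter), so this position, too, now has a step in one place, and that step shows no separable change in this assay. The configuration comparison is a clean one, and it can be read as a test of that single feature because of one structural fact: the fact that compounds 2 and 3 differ only in the configuration as drawn

As far as these compounds go, what remains open is whether a larger substituent on the same nitrogen, such as a longer chain like n-butyl, a benzyl group or a phenyl ring, would move the read-out beyond the scatter where allyl does not. Also open, from the compounds shown here alone, is whether the Z and E forms would stay indistinguishable with one of those groups in place of allyl, or with hydrogen on that nitrogen.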